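This account rests on a few compounds, and the source may have more. Where it says the series, first, only, none or still open, it means among the compounds named here.

Compound 2, `Cc1c(C)n(Cc2ccccc2)c2ncn(C3CCOCC3)c(=N)c12`: 1680 10^-6 cm/s
Compound 1, `N=c1c2c(-c3ccccc3)c(-c3ccccc3)n(Cc3ccccc3)c2ncn1CCNc1ccncc1`: 445 10^-6 cm/s

Both numbers come from an ADME assay for permeability, using PAMPA, with a stated time of 30 min, at pH 7.4; a lower number here means that the compound crosses the layer more slowly, a higher number that the compound crosses the layer faster. Of the two compounds measured, compound 2 gives the higher number; compound 1 sits clearly lower, and that gap is wider than the scatter of repeat measurements, so the two compounds are genuinely distinct in this assay. Going by the values given here, the two compounds share no single-point relationship, so no step between measured compounds is available to lean on.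

Compound 3, `Cc1c(C)n(Cc2ccccc2)c2ncn(CCCO)c(=N)c12`, is not yet measured. It differs from compound 2 in one place: 3-hydroxypropyl in place of oxan-4-yl on an aromatic nitrogen. Among the compounds with values here, with no comparable step among the measured compounds, the size of the change can only be guessed. The expectation is for a downward move, of a size that may reach just beyond the scatter but could equally stay within it; the step from compound 2 to compound 3 is expected to be a 1.9-fold lower number from compound 2 to compound 3 (0.27 log units; within the scatter). On that basis compound 3 is estimated to give 900 10^-6 cm/s in this assay, with a plausible range from 400 10^-6 cm/s to 1800 10^-6 cm/s.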

Compound 3, apparent permeability: 609 10^-6 cm/s
Compound 3: middle estimate off by 1.5-fold (0.17 log units), on the high side; low and high end bracket the measured number.
By their numbers in this assay, from the lowest: compounds 1 and 3 (each within the scatter of the next); then compound 2.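

Going by these compounds alone, this is the first step that can be read at a single place: on an aromatic nitrogen of the shared core, 3-hydroxypropyl in place of oxan-4-yl gives a 2.8-fold lower number from compound 2 to compound 3 (0.44 log units; beyond the scatter) in this assay. The group at this position can therefore shift the read-out by more than repeat measurements would, but the swap changes several things at once: a six-membered non-aromatic ring gives way to an open chain, 6 heavy atoms become 4, and 0 hydrogen-bond donors become 1, so this single step cannot separate these differences. No measurement shown here explains the lower number.

The compounds shown leave open whether the loss of the ring or the arrival of the hydroxyl hydrogen matters more, a question that a 3-methoxypropyl chain, with the same open shape but no such hydrogen, could help to answer. On these data alone, it is also open how this position would respond to a longer chain, such as 5-hydroxypentyl, or to a chain ending in an amine or a carboxylic acid.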